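Halogen swap on the fused ring of compound 3

The source may report more compounds than this note shows. Statements on the series, on what has been measured and on what is new or still open speak of the compounds shown alone.

Compounds measured so far:
compound 1, `Cc1ccc2occ(C3N=C(c4ccccc4)SS3)c(=O)c2c1`, 32%
compound 2, `O=c1c(C2N=C(c3ccccc3)SS2)coc2ccc(Cl)cc12`, 12%
compound 3, `O=c1c(C2N=C(c3ccccc3)SS2)coc2cc(Cl)c(Cl)cc12`, 50%

In a functional assay on COLO 205 cells (Homo sapiens) for inhibition, read by sulforhodamine B assay, with a stated time of 48 h, tested at 100 uM (a lower number here means less inhibition of growth, a higher number more inhibition of growth at the concentration tested), compound 3 gives 50%, the highest of the three numbers. Compound 1 lies nearest to it with 32%, and compound 2 lies furthest with 12%, both gaps beyond the scatter. The two measured steps both alter a substituent on the fused ring of the shared core: a number 20 percentage points lower from compound 1 to compound 2 (beyond the scatter), and a number 38 percentage points higher from compound 2 to compound 3 (beyond the scatter).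

Compound 4, `O=c1c(C2N=C(c3ccccc3)SS2)coc2cc(Cl)c(F)cc12`, is not yet measured. It differs from compound 3 in one place: fluoro in place of chloro on an aromatic carbon. For the measured compounds named here, no measured step exchanges one halogen for another, so neither step bears on it directly; the only related change is the chloro for hydrogen of compound 2 to compound 3, which moved the number a great deal, and that step says only that a chloro at this position matters. Replacing it with fluoro, a smaller halogen in the count given, is therefore expected to cost some inhibition, but less than removing it altogether. The expected change in this assay is a number 12 percentage points lower from compound 3 to compound 4 (beyond the scatter), a modest fall. For compound 4 the estimate is 38%, with a range from 20% to 55%.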

Compound 4, percent growth inhibition at one concentration: 45%
Beside the measured number, compound 4's estimate is 7 percentage points below it; low and high end bracket the measured number.
By their numbers in this assay, from the lowest: compound 2; then compound 1; then compounds 4 and 3 (each within the scatter of the next).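

In this assay the exchange of chloro for fluoro gives a number 5 percentage points lower from compound 3 to compound 4 (within the scatter), so on this aromatic carbon, ortho to a chloro group, the two halogens cannot be told apart. The same carbon had already shown a real response to its substituent, with a number 20 percentage points lower from compound 1 to compound 2 (beyond the scatter) when chloro took the place of methyl, so the earlier compounds left it possible that any change here would move the number; this pair shows that at least one exchange does not, as long as the neighbouring chloro group stays in place. No measurement at hand explains why the two halogens read alike here.

As far as these compounds go, it remains open whether fluoro and chloro would also read alike on this carbon without the second chloro group, since the step that added that group, a number 38 percentage points higher from compound 2 to compound 3 (beyond the scatter), was taken with chloro alone. From the compounds shown here alone, it is equally open how this carbon would respond to a group other than a halogen, such as a methoxy group, an amine or a carboxylic acid, and whether bromo or iodo would continue the match seen here.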